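Replacing Bromo on Compound 2 with Benzyl(methyl)amino

The source may report more compounds than this note shows. Statements on the series, on what has been measured and on what is new or still open speak of the compounds shown alone.

Measured compounds:
compound 1 `CN(Cc1cc(C(F)(F)F)cc(C(F)(F)F)c1)C(=O)c1cnc2ccccc2c1-c1ccccc1` — 0.03 nM
compound 2 `O=C(NCc1cc(C(F)(F)F)cc(C(F)(F)F)c1)c1c(CBr)nc2ccccc2c1-c1ccccc1` — 0.01 nM
compound 3 `CN(Cc1cc(C(F)(F)F)cc(C(F)(F)F)c1)C(=O)c1c(CBr)nc2ccccc2c1-c1ccccc1` — 52 nM

In an in vitro assay on UC11MG cells for binding affinity to Substance-P receptor (Homo sapiens), read by radioligand binding (on this read-out lower numbers stand for stronger inhibition and higher numbers for weaker inhibition), compound 2 gives 0.01 nM, the lowest number of the three; compound 1 comes nearest, compound 3 lies furthest away. Compound 4 `CN(Cc1ccccc1)Cc1nc2ccccc2c(-c2ccccc2)c1C(=O)NCc1cc(C(F)(F)F)cc(C(F)(F)F)c1` differs from compound 2 by benzyl(methyl)amino in place of bromo on a saturated chain carbon bound to an aromatic carbon. Neither measured step touches that carbon: a 1700-fold higher number from compound 1 to compound 3 (3.24 log units; beyond the scatter) concerns bromomethyl against hydrogen, and a 5200-fold higher number from compound 2 to compound 3 (3.72 log units; beyond the scatter) concerns methyl on the amide nitrogen, both large. What an exchange at the saturated chain carbon does is therefore unknown from these data, and a cautious expectation leans toward only a modest change. Compound 4 is expected to show a 5.0-fold higher number from compound 2 to compound 4 (0.70 log units; beyond the scatter). The estimate for compound 4 in this assay is 0.05 nM, with a range from 0.005 nM to 0.5 nM.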

Compound 4, half-maximal inhibitory concentration: 180 nM
The estimate for compound 4 lay 3600-fold (3.56 log units) below the measured number, and the stated range ends below it.
By their numbers in this assay, from the lowest: compound 2; then compound 1; then compound 3; then compound 4.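

In this assay, the saturated chain carbon bound to an aromatic carbon proves highly sensitive to exchange: benzyl(methyl)amino in place of bromo gives an 18000-fold higher number from compound 2 to compound 4 (4.26 log units; beyond the scatter). Compound 4 keeps the amide hydrogen, so that hydrogen alone does not secure a low number in this series. No available evidence explains the loss.

The compounds shown leave open whether a smaller group on that carbon, such as dimethylamino or hydroxyl, would keep the low number. They also leave open whether the benzyl ring or the amine nitrogen accounts for the step.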